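The source may report more compounds than this note shows. Statements on the series, on what has been measured and on what is new or still open speak of the compounds shown alone.

Compound 1 `COc1cc2nc(N3CCN(S(=O)(=O)c4cccc5ccccc45)CC3)nc(N)c2cc1OC`: 14000 nM in a functional assay on PC-3 cells (Homo sapiens) for inhibition; on this read-out higher numbers stand for weaker inhibition and lower numbers for stronger inhibition
Compound 2 `COc1cc2nc(N3CCN(S(=O)(=O)c4ccc5ccccc5c4)CC3)nc(N)c2cc1OC`: 15000 nM in this assay

Within the data shown here, compound 1 stands with the lowest of the two numbers in this assay, and the only step between measured compounds, a 1.1-fold higher number from compound 1 to compound 2 (0.03 log units; within the scatter), lies within the scatter. Compound 3 `COc1cc2nc(N3CCN(S(=O)(=O)c4cccc5c(N(C)C)cccc45)CC3)nc(N)c2cc1OC` differs from compound 1 by dimethylamino in place of hydrogen on an aromatic carbon. Among the measured compounds shown here, no measured step touches a dimethylamino group, and the one step at hand concerns only the sulfonyl substituent, so nothing indicates a change beyond the scatter in this assay. Compound 3 is therefore expected to give 14000 nM, in the range 5000 nM to 40000 nM, which amounts to an expected step of no change at the digits printed from compound 1 to compound 3 (within the scatter).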

Compound 3, half-maximal inhibitory concentration: 29000 nM
For compound 3 the middle estimate is 2.1-fold (0.32 log units) below the measured one; the measured number falls inside the stated range.
By their numbers in this assay, from the lowest: compounds 1, 2 and 3 (each within the scatter of the next, the first and the last beyond it).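

The earlier pair changed only the attachment of the naphthalene, from naphthalen-1-yl to naphthalen-2-yl, and gave no step beyond the scatter. Here, dimethylamino in place of hydrogen on an aromatic carbon of that ring system gives a 2.1-fold higher number from compound 1 to compound 3 (0.32 log units; beyond the scatter) in this assay, so this position responds to substitution, modestly and towards weaker inhibition. No measurement at hand bears on why this step occurs. From the compounds shown here alone, whether a primary amine, a methoxy group or a carboxylic acid on the same carbon would give a similar step stays open. So does whether dimethylamino would act alike on the naphthalen-2-yl group of compound 2.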